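Trimming a trifluoromethyl group from a diaryl urea

The source may hold more compounds than are shown below. What is called first, only, known or untested is meant among the compounds shown, and "the series" means these compounds.

Measured compounds:
- compound 1 `O=C(Nc1cccc(-n2cc(-c3ccncc3)c(-c3cc(O)cc(Cl)c3)n2)c1)Nc1ccc(Cl)c(C(F)(F)F)c1`: 92%
- compound 2 `COc1cc(Cl)cc(-c2nn(-c3cccc(NC(=O)Nc4ccc(Cl)c(C(F)(F)F)c4)c3)cc2-c2ccncc2)c1`: 69%
- compound 3 `COc1cc(Cl)cc(-c2nn(-c3cccc(NC(=O)Nc4cc(C(F)(F)F)cc(C(F)(F)F)c4)c3)cc2-c2ccncc2)c1`: 95%

In a functional assay on NCI/ADR-RES cells (Homo sapiens) for inhibition, read by sulforhodamine B assay, with a stated time of 48 h, tested at 0.1 uM (on this read-out lower numbers stand for a stronger effect and higher numbers for a weaker effect at the one concentration tested), compound 3 gives 95%, the highest of the three numbers, which here means the weakest effect. Compound 1 sits close to it, within the usual scatter, while compound 2 is clearly lower and therefore stronger. Among the compounds with values here, the only step measured so far, a number 23 percentage points lower from compound 1 to compound 2 (beyond the scatter), concerns the oxygen substituent on the shared core and says nothing about the urea end of the molecule.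

Compound 4 `COc1cc(Cl)cc(-c2nn(-c3cccc(NC(=O)Nc4cccc(C(F)(F)F)c4)c3)cc2-c2ccncc2)c1` is compound 3 with one group removed: hydrogen in place of trifluoromethyl on an aromatic carbon. Within the data shown here, no measured step touches this part of the structure, so there is no direct guide. Compound 3 already lies near the top of the read-out, and with nothing to suggest a shift, the expected step of a number 5 percentage points lower from compound 3 to compound 4 (within the scatter) is none beyond the scatter. Compound 4 is therefore estimated at 90%, with a likely range from 72% to 100%.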

Compound 4, a percentage reported as activity, at one concentration (the size of the read-out at that concentration, not a potency): 98%
Compound 4: the middle estimate sits 8 percentage points below what was measured, within the range that was stated.
By their numbers in this assay, from the lowest: compound 2; then compounds 1, 3 and 4 (each within the scatter of the next).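

In this assay, trading a trifluoromethyl group for hydrogen at the urea end of the molecule makes no clear difference: a number 3 percentage points higher from compound 3 to compound 4 (within the scatter). Hydrogen in place of chloro at that same end does matter, with a number 29 percentage points higher from compound 2 to compound 4 (beyond the scatter), so this end of the molecule does respond to change, but the size of the response depends on which group is removed. No measurement shown here offers an explanation for this contrast.

On these data alone, it remains open whether another group in the place of the chloro, such as an amine or a nitrile, would match or surpass the effect seen with compound 2. A single concentration also leaves open how these compounds would compare across a range of concentrations.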